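Swapping fluoro for iodo on compound 3

A few compounds are considered here, and "the series" means these few. Any claim that something is new, unique, unknown or untested is made for them only; others in the source may bear on it.

Compound 1 `CNC1=NS(=O)(=O)c2cc(F)ccc2N1` gives > 300 uM as a limit
Compound 2 `CCNC1=NS(=O)(=O)c2cc(F)ccc2N1` gives > 300 uM as a limit
Compound 3 `CC(C)NC1=NS(=O)(=O)c2cc(F)ccc2N1` gives 43.1 uM as a number

In a functional assay (aorta) with Rattus norvegicus as the target (on this read-out higher numbers stand for an effect only at larger amounts of compound and lower numbers for an effect already at smaller amounts), only compound 3 gives a true number, and its 43.1 uM is the one measured point to build on. Compound 4 `CC(C)NC1=NS(=O)(=O)c2cc(I)ccc2N1` differs from compound 3 at one place (iodo in place of fluoro on an aromatic carbon) with iodo in place of fluoro on an aromatic carbon. The readable steps are an at least 6.9-fold lower number from compound 1 to compound 3 (0.84 log units; beyond the scatter) and an at least 6.9-fold lower number from compound 2 to compound 3 (0.84 log units; beyond the scatter) and both sit on the amine side of the molecule, so neither measures a change on that aromatic carbon. They show that one small change can move this read-out beyond the scatter, yet no swap of fluoro for another group has been measured. The expectation is therefore a modest step that leans towards a lower number, with the direction far from certain. The estimate expects a 2.2-fold lower number from compound 3 to compound 4 (0.33 log units; beyond the scatter) as the likely size of the change. For compound 4 the estimated value is 20 uM within an expected range of 4 uM to 90 uM in this read-out.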

Compound 4, concentration for half-maximal effect: 7.7 uM
Beside the measured number, compound 4's estimate is 2.6-fold (0.41 log units) above it; low and high end bracket the measured number.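

In this assay the aromatic carbon now has a readable effect: iodo in place of fluoro gives a 5.6-fold lower number from compound 3 to compound 4 (0.75 log units; beyond the scatter) and so shows that this position, and not only the amine side, can move the read-out beyond the scatter. Among these compounds, this step is the first here with a true number at both ends, so its size can be read directly. Among the compounds shown here, compound 1 and compound 2 each stop at a limit, which gives the earlier steps only a minimum size: the limit of > 300 uM in this assay, at which 2 of the 4 values shown sit.

From the compounds shown here alone, whether chloro or bromo on this carbon would fall between compound 3 and compound 4 stays open, as does the effect of an amine or a carboxylic acid there. Also open, going by these compounds, is whether iodo would give a similar step with the methylamino or ethylamino side chains of compound 1 and compound 2.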